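The compounds below may be only part of what the source reports. "The series", "measured", "known", "first", "only" and "open" are said of these compounds alone.

Measured compounds:

compound 1 `CCc1cnc(N2CCC(c3nc(COc4ccc(/C=C5\CC(=O)NC5=O)cc4F)cs3)CC2)nc1` gives 49 nM in a functional assay on cells for agonist activity at Glucose-dependent insulinotropic receptor (Homo sapiens), read by a luciferase reporter, with a stated time of 6 h; a lower number here means that less compound is needed, a higher number that more compound is needed for the effect
compound 2 `CC(C)(C)OC(=O)N1CCC(c2nc(COc3ccc(/C=C4\CC(=O)NC4=O)cc3F)cs2)CC1` gives 157 nM in this assay
compound 3 `CCc1cnc(N2CCC(c3nc(COc4ccc(-n5cnnn5)cc4)cs3)CC2)nc1` gives 87 nM in this assay

Compound 1 and compound 2 differ in one place: tert-butoxycarbonyl in place of 5-ethylpyrimidin-2-yl on an amine nitrogen in a ring. That change produced a 3.2-fold higher number from compound 1 to compound 2 (0.51 log units; beyond the scatter). Compound 3 stands nearest to compound 1, and its number is within the scatter of both compound 1 and compound 2, so no order among these three can be read from the values of compound 3 against either. The difference between the core of compound 3 and the core of compound 1 is not broken down here.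

Compound 4 `CC(C)(C)OC(=O)N1CCC(c2nc(COc3ccc(-n4cnnn4)cc3)cs2)CC1` is not yet measured in this assay. It differs from compound 3 in one place: tert-butoxycarbonyl in place of 5-ethylpyrimidin-2-yl on an amine nitrogen in a ring. This is the same change as the one from compound 1 to compound 2, made on the same kind of position, and it occurs twice among the compounds shown. The only basis for an expectation is that earlier step; whether the different core of compound 3 alters the size of the step cannot be told from one example.

The step from compound 3 to compound 4 is expected to be a 3.2-fold higher number from compound 3 to compound 4 (0.51 log units; beyond the scatter) in this assay, resting on compound 1 to compound 2 giving a 3.2-fold higher number from compound 1 to compound 2 (0.51 log units; beyond the scatter). Compound 4 is estimated at 280 nM in this assay, with a range from 120 nM to 650 nM expected to cover most repeat measurements.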

Compound 4, half-maximal effective concentration: 103 nM
The estimate for compound 4 lay 2.7-fold (0.43 log units) above the measured number; the whole stated range lies above it.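

Tert-butoxycarbonyl in place of 5-ethylpyrimidin-2-yl on an amine nitrogen in a ring gave a 1.2-fold higher number from compound 3 to compound 4 (0.07 log units; within the scatter) in this assay, so on this core the two groups cannot be told apart by this read-out. The size of the step did not carry over between the two cores, and a step taken from one core is therefore not a safe guide to the same change on the other: the same change on two cores in this assay, a 3.2-fold higher number (0.51 log units; beyond the scatter) from compound 1 to compound 2 and a 1.2-fold higher number (0.07 log units; within the scatter) from compound 3 to compound 4, 2.7-fold (0.43 log units) apart, beyond the scatter of two such steps

What stays unshown is which part of the cores goes with this gap, as they differ in more than one place, and two pairs give no rule for how the change would behave on a third core.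

The compounds shown leave open whether a core carrying only one of those differences would give a step like the larger or the smaller one. They also leave open how other groups on the same ring nitrogen would behave across the two cores, such as an acetyl group, a methylsulfonyl group or a pyrimidin-2-yl group with a longer chain in place of the ethyl.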